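From benzoyl to phenyl: a half-life in question

The source may hold more compounds than are shown below. What is called first, only, known or untested is meant among the compounds shown, and "the series" means these compounds.

Compound 1 (`O=C(c1ccccc1)N1CCC(C(=O)N2N=CCC2c2ccccc2)CC1`): 1.72 h
Compound 2 (`CC(C)C(=O)N1N=CCC1c1ccccc1`): > 1.5 h (a limit)

For the measured compounds named here, in an ADME assay on microsomes (Homo sapiens) for metabolic stability (on this read-out lower numbers stand for a shorter-lived compound and higher numbers for a longer-lived compound), compound 1 gives 1.72 h as the only actual number among the measured compounds. Compound 2 gives > 1.5 h as a limit of the assay and not a number. Compound 1 therefore stands as the sole numeric reference, with no second number to rank it against.

Compound 3 (`O=C(C1CCN(c2ccccc2)CC1)N1N=CCC1c1ccccc1`) keeps the shared core and carries phenyl in place of benzoyl on an amine nitrogen in a ring. Going by the values given here, no measured step between compounds that differ in one place is available for comparison. The expectation starts from compound 1 at 1.72 h and rests on the structural change alone. In this assay the step of a 1.4-fold lower number from compound 1 to compound 3 (0.16 log units; within the scatter) is expected to be small, towards a shorter half-life, and not far from the usual scatter. For compound 3 the estimate is 1.2 h as the expected half-life, within a range of 0.5 h to 2.5 h in the measurement to come.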

Compound 3, half-life: > 1.5 h
Compound 3 gave a limit, no number (the forecaster's own chance of this, stated with the estimate: 25%); at least 1.2-fold (0.09 log units) between middle value and limit.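

In this assay compound 3 gives > 1.5 h as a limit of the assay and not a number. The step from compound 1 to compound 3 therefore cannot be read. The compounds shown leave open how the half-life of compound 3 compares with that of compound 1, and so whether phenyl in place of benzoyl on an amine nitrogen in a ring changes it at all.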